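The source may report more compounds than this note shows. Statements on the series, on what has been measured and on what is new or still open speak of the compounds shown alone.

Compound 1 `CCCCCCCCNc1nc(SCc2ccc(C(F)(F)F)cc2)nc2ccccc12` and compound 2 `FC(F)(F)c1ccc(CSc2nc(Nc3ccccc3C(F)(F)F)c3ccccc3n2)cc1` share one core and differ in the group on the ring nitrogen. In a functional assay on HGC-27 cells (Homo sapiens) for cytotoxicity, read by MTT assay, with a stated time of 72 h (a higher number here means a weaker inhibitor, a lower number a stronger inhibitor), compound 1 gives 13400 nM. Compound 2 in this assay reaches only the limit of > 50000 nM, which is a bound of the assay and not a number. The change from octyl to 2-(trifluoromethyl)phenyl therefore reads as an at least 3.7-fold higher number from compound 1 to compound 2 (0.57 log units; beyond the scatter), with compound 2 sitting at the limit of > 50000 nM in this assay, at which 1 of the 2 values shown sits. Compound 3 `CCOc1ccccc1Nc1nc(SCc2ccc(C(F)(F)F)cc2)nc2ccccc12` keeps the aryl group of compound 2 and alters it by ethoxy in place of trifluoromethyl on an aromatic carbon. No measured step tests a swap on that aryl ring; the only step shown concerns the nitrogen substituent as a whole, and it placed compound 2 beyond the measurable range. With compound 2 at the limit, the step to compound 3 cannot be sized from the data, and the expectation is that compound 3 stays weak. Compound 3 is estimated at 50000 nM, within 15000 nM to 100000 nM, which means an expected step of a number no higher from compound 2 to compound 3 (the limit leaves the size open).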

Compound 3, half-maximal inhibitory concentration: > 50000 nM
Compound 3: a limit, no number (the forecaster's own chance of this, stated with the estimate: 55%); the middle value lies on the limit itself.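

Compound 3 shows that the loss seen with compound 2 is not tied to trifluoromethyl: with ethoxy on the aryl ring, the change from octyl to 2-ethoxyphenyl again reads in this assay as an at least 3.7-fold higher number from compound 1 to compound 3 (0.57 log units; beyond the scatter). The effect of ethoxy in place of trifluoromethyl on that aromatic carbon cannot be read, because compound 2 and compound 3 both stop at the same bound of the assay: the limit of > 50000 nM in this assay, at which 2 of the 3 values shown sit. Among the three compounds shown, the two with an aryl group on the nitrogen give only a limit, and compound 1, with its octyl chain, is the only one that gives a number.

From the compounds shown here alone, what remains open is how far below or beyond that limit compound 2 and compound 3 truly lie, and so whether the aryl ring tolerates any substituent at all in this assay. Going by these compounds, it is also open whether a hexyl or decyl chain on the nitrogen would shift the value of compound 1, or whether an amine or a carboxylic acid on the aryl ring would bring a measurable value.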